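Swapping the Side Chain of Compound 2: an Expected Activity

The compounds below may be only part of what the source reports. "The series", "measured", "known", "first", "only" and "open" are said of these compounds alone.

Compound 2 `CSCC[C@H](NC(=O)CN(c1nc(Cl)nc2[nH]cnc12)C1CC1)C(=O)OCc1ccccc1`: 44.6%
Compound 3 `C[C@H](NC(=O)CN(c1nc(Cl)nc2[nH]cnc12)C1CC1)C(=O)O`: 43.5%
Compound 1 `O=C(O)[C@@H]1CCCN1C(=O)CN(c1nc(Cl)nc2[nH]cnc12)C1CC1`: 26%

All three numbers come from a functional assay on the whole organism (Tail, strain ICR) with Mus musculus as the target, in the tail flick test, with a stated time of 90 min, at a dose of 25 umol/kg by the oral route; on this read-out lower numbers stand for a weaker effect and higher numbers for a stronger effect at the one dose given. Compound 2 shows the highest number of the three; its gap to compound 3 lies within the scatter, while its gap to compound 1 lies beyond it. Compound 4 `NCCCC[C@H](NC(=O)CN(c1nc(Cl)nc2[nH]cnc12)C1CC1)C(=O)OCc1ccccc1` differs from compound 2 by 2-aminoethyl in place of methylsulfanyl on a saturated chain carbon, three bonds along the chain from an amide-type nitrogen and a carbonyl carbon. Among the compounds with values here, no measured pair tests this exchange. Because a number 17.5 percentage points higher from compound 1 to compound 3 (beyond the scatter) is only modest and concerns a different group on the carbonyl carbon, a step within the scatter is expected, a number 0.4 percentage points higher from compound 2 to compound 4 (within the scatter), with allowance for a small move in either direction. Compound 4 is therefore estimated at 45%, ranging from 25% to 65% in this assay.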

Compound 4, a percentage reported as activity, at one dose (the size of the read-out at that dose, not a potency): 35.3%
The estimate for compound 4 lay 9.7 percentage points above the measured number; the measured number falls inside the stated range.
By their numbers in this assay, from the lowest: compounds 1, 4, 3 and 2 (each within the scatter of the next, the first and the last beyond it).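

In this assay, 2-aminoethyl in place of methylsulfanyl on this saturated chain carbon gives a number 9.3 percentage points lower from compound 2 to compound 4 (within the scatter), so this position tolerates the exchange of a sulfur-bearing chain end for an amine-bearing one without a change that can be told from the scatter. The benzyl ester stays the same in both compounds, which confines the comparison to this one chain. Nothing measured here accounts for the result.

On these data alone, whether a hydroxyl group, a carboxylic acid or a longer amine chain on the same carbon would move the number beyond the scatter stays open. So does how the free carboxylic acid of compound 4 would compare with its benzyl ester.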